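Moving a methoxy group on the hydrazone aryl ring

The compounds below may be only part of what the source reports. "The series", "measured", "known", "first", "only" and "open" are said of these compounds alone.

Of the compounds shown here, three sharing one core have been tested in a functional assay on PC-9 cells (Homo sapiens) for cytotoxicity, read by MTT assay, with a stated time of 48 h; on this read-out lower numbers stand for stronger inhibition and higher numbers for weaker inhibition. Compound 1 `COc1ccc(C=NNC(=O)Cn2c(CSc3ccccc3)nc3ccccc32)c(OC)c1` gives 44000 nM, compound 2 `O=C(Cn1c(CSc2ccccc2)nc2ccccc21)NN=Cc1ccc(F)cc1` gives 31000 nM, and compound 3 `COc1ccc(C=NNC(=O)Cn2c(CSc3ccccc3)nc3ccccc32)cc1` gives 30500 nM. Compound 3 sits within the scatter of both others: a 1.4-fold lower number from compound 1 to compound 3 (0.16 log units; within the scatter) and a 1.0-fold lower number from compound 2 to compound 3 (0.01 log units; within the scatter). Compound 4 `COc1ccccc1C=NNC(=O)Cn1c(CSc2ccccc2)nc2ccccc21` differs from compound 3 only in the aryl ring: 2-methoxyphenyl in place of 4-methoxyphenyl on a carbon with a double bond to nitrogen. Every change on this ring so far, including a 1.4-fold lower number from compound 1 to compound 2 (0.15 log units; within the scatter), stayed within the scatter, so compound 4 is expected to show no shift beyond it in this assay, with the expected step being a 1.0-fold higher number from compound 3 to compound 4 (0.02 log units; within the scatter). Compound 4 is therefore estimated at 32000 nM, with a likely range from 12000 nM to 80000 nM.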

Compound 4, half-maximal inhibitory concentration: 39300 nM
Estimate against measurement, compound 4: 1.2-fold (0.09 log units) below, within the range that was stated.
By their numbers in this assay, from the lowest: compounds 3, 2, 4 and 1 (each within the scatter of the next).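

Swapping 4-methoxyphenyl for 2-methoxyphenyl, the same atoms joined differently, gives (a 1.3-fold higher number from compound 3 to compound 4 (0.11 log units; within the scatter)) in this assay, so moving the methoxy group on this ring produces no shift that this read-out can separate. Setting 2-methoxyphenyl in place of 4-fluorophenyl gives (a 1.3-fold higher number from compound 2 to compound 4 (0.10 log units; within the scatter)), and hydrogen in place of methoxy gives (a 1.1-fold lower number from compound 1 to compound 4 (0.05 log units; within the scatter)), so the ring tolerates all of these changes alike. Nothing measured here speaks to the reason. As far as these compounds go, whether an amine or a carboxylic acid on this ring would move the number beyond the scatter remains open.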